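Working notes: bromo in place of chloro, compound 4

This account rests on a few compounds, and the source may have more. Where it says the series, first, only, none or still open, it means among the compounds named here.

Measured so far in a functional assay on NCI-H460 cells (Homo sapiens) for inhibition, read by MTT assay, with a stated time of 24 h, tested at 100 ug/mL; a lower number here means less inhibition of growth, a higher number more inhibition of growth at the concentration tested:
- compound 1 `O=C(CCCCC1CCSS1)Nc1ccc(Br)cn1`: 52%
- compound 2 `O=C(CCCCC(S)CCS)Nc1ccccn1`: 11.7%
- compound 3 `O=C(CCCCC(S)CCS)Nc1ccc(Cl)cn1`: 55.8%

In this assay compound 3 gives 55.8%, which lies within the scatter of compound 1 at 52%. Only compound 2 at 11.7% is separated from it beyond the scatter.

The next compound is compound 4 `O=C(CCCCC(S)CCS)Nc1ccc(Br)cn1`. Its change from compound 3 is bromo in place of chloro on an aromatic carbon.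

Among the measured compounds shown here, one measured step bears on this change: a number 44.1 percentage points higher from compound 2 to compound 3 (beyond the scatter), a large step for chloro in place of hydrogen. It shows that this ring position can matter, but it compares a substituent with hydrogen, and no exchange of chloro for bromo has been measured. Compound 1 also carries bromo and gives 52%, but its side chain differs from that of compound 4, so it is only indirect support. On these data, no step beyond the scatter is expected in this assay.

The expected change is a number 0.8 percentage points lower from compound 3 to compound 4 (within the scatter). For compound 4 the estimated value is 55%, with an expected range of 42% to 68%.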

Compound 4, percent growth inhibition at one concentration: 55.9%
For compound 4 the middle estimate is 0.9 percentage points below the measured one; the range from low to high includes it.
By their numbers in this assay, from the lowest: compound 2; then compounds 1, 3 and 4 (each within the scatter of the next).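

In this assay, bromo in place of chloro on this aromatic carbon gives a number 0.1 percentage points higher from compound 3 to compound 4 (within the scatter), so the two halogens cannot be told apart here when the open side chain is present. Bromo in place of hydrogen gives a number 44.2 percentage points higher from compound 2 to compound 4 (beyond the scatter), a large step that matches a number 44.1 percentage points higher from compound 2 to compound 3 (beyond the scatter) for chloro in place of hydrogen, so the gain over hydrogen in this series is now seen with two different halogens rather than one. With bromo held constant on the ring, the change of side chain gives a number 3.9 percentage points higher from compound 1 to compound 4 (within the scatter), which separates the open chain from the five-membered non-aromatic ring with 2 hetero atoms by no more than the scatter; no measured data offer an explanation for any of these results.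

On these data alone, it remains open whether the level result for the two halogens extends to other groups at this position, such as an amine, a methoxy or a nitrile, or to a longer chain in place of the present side chain. As far as these compounds go, it is also open whether chloro and bromo would stay level at concentrations other than the single one tested.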